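Methylsulfanyl in place of chloro on the compound 2 scaffold

The compounds below may be only part of what the source reports. "The series", "measured", "known", "first", "only" and "open" are said of these compounds alone.

In a functional assay on the whole organism (strain Sprague-Dawley) for inhibition, with Rattus norvegicus as the target (on this read-out higher numbers stand for an effect only at larger amounts of compound and lower numbers for an effect already at smaller amounts), compound 2 `O=c1c(-c2nn[nH]n2)c[nH]c2c(Cl)cccc12` gives 0.078 mg/kg, the lowest of the two numbers available; compound 1 `COc1cccc2cc(C(=O)O)cnc12` gives 25 mg/kg, a gap well beyond the scatter. Compound 3 `O=c1c(-c2nn[nH]n2)c[nH]c2c(Cl)ccc(Cl)c12` returns only a limit, > 0.156 mg/kg, namely (the limit of > 0.156 mg/kg in this assay, at which 1 of the 3 values shown sits). Among the compounds with values here, the single measured step, an at least 2.0-fold higher number from compound 2 to compound 3 (0.30 log units; that floor lies within the scatter), concerns chloro in place of hydrogen and leaves the group changed here untouched, so no measured step bears directly on the present change.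

Compound 4 `CSc1cccc2c(=O)c(-c3nn[nH]n3)c[nH]c12` differs from compound 2 by methylsulfanyl in place of chloro on an aromatic carbon. Within the data shown here, with no precedent for methylsulfanyl, the expectation rests on compound 2 alone and carries wide uncertainty; a modest shift is expected, a 1.9-fold higher number from compound 2 to compound 4 (0.28 log units; within the scatter), with no firm direction. Compound 4 is therefore estimated at 0.15 mg/kg, within 0.04 mg/kg to 0.6 mg/kg.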

Compound 4, minimum effective dose: 10 mg/kg
Estimate against measurement, compound 4: 67-fold (1.82 log units) below, outside the stated range (above it).
By their numbers in this assay, from the lowest: compound 2; then compound 4; then compound 1.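

Exchanging chloro for methylsulfanyl at this position is far from neutral in this assay: a 130-fold higher number from compound 2 to compound 4 (2.11 log units; beyond the scatter). Within the data shown here, this is the first step on the shared core that lies beyond the scatter, so the position responds strongly to this change, which the earlier compounds could not show. No measurement shown accounts for this step.

From the compounds shown here alone, it remains open whether the effect depends on removing chloro or on introducing methylsulfanyl. Going by these compounds, it also remains open whether methyl, bromo or an amine at this position would keep the low number of compound 2.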